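Moving the hydroxyl on a biaryl pyridine series

The source may report more compounds than this note shows. Statements on the series, on what has been measured and on what is new or still open speak of the compounds shown alone.

Compound 1 `Oc1cccc(-c2cc(-c3ccccc3)cc(-c3cccs3)n2)c1`: 18900 nM
Compound 2 `Oc1ccc(-c2cc(-c3ccccc3)cc(-c3cccs3)n2)cc1`: 3700 nM
Compound 3 `Oc1cccc(-c2cc(-c3ccccc3)nc(-c3ccco3)c2)c1`: 34900 nM

Three compounds were measured in a functional assay on DU-145 cells (Homo sapiens) for cytotoxicity, read by ELISA, with a stated time of 2 days; on this read-out lower numbers stand for stronger inhibition and higher numbers for weaker inhibition. Compound 1 gives 18900 nM and compound 2 gives 3700 nM; the change between them is 4-hydroxyphenyl in place of 3-hydroxyphenyl on an aromatic carbon, and it produced a 5.1-fold lower number from compound 1 to compound 2 (0.71 log units; beyond the scatter). Compound 3 gives 34900 nM; its number is close to that of compound 1 and within the scatter of it, while its gap to compound 2 lies beyond the scatter. The difference between the core of compound 3 and the core of compound 1 is not broken down here.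

Compound 4 `Oc1ccc(-c2cc(-c3ccccc3)nc(-c3ccco3)c2)cc1` has not yet been measured. It differs from compound 3 by 4-hydroxyphenyl in place of 3-hydroxyphenyl on an aromatic carbon. Among the measured compounds shown here, this is the same kind of change as the one from compound 1 to compound 2, but not the same: in compound 1 the group sits next to the ring nitrogen and meta to a thiophen-2-yl group, whereas in compound 3 it sits opposite the ring nitrogen and meta to a furan-2-yl group.

For the measured compounds named here, because the one measured example of this change gave a 5.1-fold lower number from compound 1 to compound 2 (0.71 log units; beyond the scatter), a step of similar direction and size is expected from compound 3 to compound 4, namely a 5.0-fold lower number from compound 3 to compound 4 (0.70 log units; beyond the scatter). Going by the values given here, compound 4 is therefore estimated to give 7000 nM in this assay, with a range from 2500 nM to 20000 nM, the wider range reflecting that only one prior example supports the expectation.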

Compound 4, half-maximal inhibitory concentration: 8600 nM
Compound 4: middle estimate off by 1.2-fold (0.09 log units), on the low side, within the range that was stated.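

In this assay, placing 4-hydroxyphenyl in place of 3-hydroxyphenyl on the second core again gave a lower number, with a 4.1-fold lower number from compound 3 to compound 4 (0.61 log units; beyond the scatter) in the same direction as on the first core. Set side by side, the two steps cannot be told apart, so in this small set the change carried over from one core to the other with its direction and approximate size intact: the same change on two cores in this assay, a 5.1-fold lower number (0.71 log units; beyond the scatter) from compound 1 to compound 2 and a 4.1-fold lower number (0.61 log units; beyond the scatter) from compound 3 to compound 4, 1.3-fold (0.10 log units) apart, within the scatter of two such steps. Among the compounds shown here, this does not show that the step is general or why it occurs, since it rests on only two pairs in a single cell assay, and the two cores differ both in where the hydroxyphenyl group sits relative to the ring nitrogen and in whether they carry a thiophen-2-yl or a furan-2-yl group, so these two differences cannot be separated.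

The compounds shown leave open whether the step would persist if the hydroxyl gave way to a methoxy group, an amine or a carboxylic acid. For the compounds shown here, they also leave open how thiophen-2-yl and furan-2-yl compare when only that group changes on one core, with the hydroxyphenyl group held in place.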